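One Carbon More in a Phenyl-Tipped Chain

The compounds below may be only part of what the source reports. "The series", "measured", "known", "first", "only" and "open" are said of these compounds alone.

In a functional assay on PC-3 cells (Homo sapiens) for cytotoxicity, read by sulforhodamine B assay, with a stated time of 5 days (a higher number here means a weaker inhibitor, a lower number a stronger inhibitor), compound 3 `O=C(CCCCCCCCc1ccccc1)N[C@H]1CCOC1=O` gives 67000 nM and compound 1 `O=C(CCCCCCCCCCc1ccccc1)N[C@H]1CCOC1=O` gives 66000 nM so these two sit within the scatter of each other. Compound 2 `O=C(CCCCCCCCCCCc1ccccc1)N[C@H]1CCOC1=O` shows > 100000 nM which is a limit and not a number. Compound 4 `O=C(CCCCCCCCCc1ccccc1)N[C@H]1CCOC1=O` differs from compound 3 by benzyl in place of phenyl on a saturated chain carbon, eight bonds along the chain from a carbonyl carbon with benzyl in place of phenyl on a saturated chain carbon, eight bonds along the chain from a carbonyl carbon. Among the compounds with values here, two measured steps bear on this change: one shows a 1.0-fold higher number from compound 1 to compound 3 (0.01 log units; within the scatter) and the other shows an at least 1.5-fold higher number from compound 1 to compound 2 (0.18 log units; that floor lies within the scatter) and both lie within the scatter. No step beyond the scatter is therefore expected in this assay and the estimated step is a 1.0-fold lower number from compound 3 to compound 4 (0.01 log units; within the scatter) for now. For compound 4 the estimated value is 66000 nM with an expected range from 35000 nM to 100000 nM in this measurement.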

Compound 4, half-maximal inhibitory concentration: 75000 nM
Compound 4: middle estimate off by 1.1-fold (0.06 log units), on the low side, within the range that was stated.
By their numbers in this assay, from the lowest: compounds 1, 3 and 4 (each within the scatter of the next). At a limit, above all of these: compound 2.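

In this assay, benzyl in place of phenyl at this place on the chain gives a 1.1-fold higher number from compound 3 to compound 4 (0.05 log units; within the scatter), and taking one carbon off the longer chain gives a 1.1-fold higher number from compound 1 to compound 4 (0.06 log units; within the scatter). Compounds 1, 3 and 4 therefore form a flat stretch, with this added chain length making no difference beyond the scatter. Compound 2 stands at a limit and not a number, so an at least 1.3-fold lower number from compound 2 to compound 4 (0.12 log units; that floor lies within the scatter) is only a floor.

Open still is how a much shorter chain, or an amine in place of the phenyl, would read in this assay.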